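The source may report more compounds than this note shows. Statements on the series, on what has been measured and on what is new or still open speak of the compounds shown alone.

Of the compounds shown here, three that share one core have been tested in a functional assay on HOP-92 cells (Homo sapiens) for inhibition, read by sulforhodamine B assay, with a stated time of 48 h; on this read-out higher numbers stand for weaker inhibition of growth and lower numbers for stronger inhibition of growth. Compound 1 `O=C(Cc1csc2nc(-c3ccc(Br)cc3)cn12)N/N=C/c1ccccc1O` gives 14500 nM, the lowest of the three numbers and therefore the strongest inhibition of growth among them. Compound 2 `O=C(Cc1csc2nc(-c3ccc(Br)cc3)cn12)N/N=C/c1ccc(O)cc1` gives 69200 nM, and compound 3 `COc1cccc(OC)c1/C=N/NC(=O)Cc1csc2nc(-c3ccc(Br)cc3)cn12` gives 35500 nM. Both exchanges of the ring on the carbon with a double bond to nitrogen moved the number upward: a 4.8-fold higher number from compound 1 to compound 2 (0.68 log units; beyond the scatter) and a 2.4-fold higher number from compound 1 to compound 3 (0.39 log units; beyond the scatter). Compound 4 `O=C(Cc1csc2nc(-c3ccc(Br)cc3)cn12)N/N=C/c1ccc(Cl)cc1Cl` has not yet been measured; it differs from compound 1 in one place (2,4-dichlorophenyl in place of 2-hydroxyphenyl on a carbon with a double bond to nitrogen). Going by the values given here, no measured compound carries chlorine on the carbon with a double bond to nitrogen, so the two steps from compound 1 are the only guide, and both point toward weaker inhibition of growth once the 2-hydroxyphenyl is replaced. A modest step in that same direction is therefore expected, a 2.2-fold higher number from compound 1 to compound 4 (0.34 log units; beyond the scatter). In this assay compound 4 is estimated at 32000 nM, with a range from 10000 nM to 95000 nM.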

Compound 4, concentration for total growth inhibition: > 100000 nM
Compound 4 ended at the assay's limit; the forecaster's own chance of this, stated with the estimate: 5%; middle value at least 3.1-fold (0.49 log units) away from the limit.
By their numbers in this assay, from the lowest: compound 1; then compounds 3 and 2 (each within the scatter of the next). At a limit, above all of these: compound 4.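

Compound 4 stands at a limit of this assay, which is not a number: the limit of > 100000 nM in this assay, at which 1 of the 4 values shown sits. Replacing 2-hydroxyphenyl with the first ring here that carries chlorine gives an at least 6.8-fold higher number from compound 1 to compound 4 (0.83 log units; beyond the scatter), and the change from 2,6-dimethoxyphenyl gives an at least 2.8-fold higher number from compound 3 to compound 4 (0.44 log units; beyond the scatter), so every ring exchanged for 2-hydroxyphenyl so far has weakened inhibition of growth, and 2,4-dichlorophenyl does so at least as far as the limit allows. Against 4-hydroxyphenyl the step reads only an at least 1.4-fold higher number from compound 2 to compound 4 (0.15 log units; that floor lies within the scatter), so compound 4 cannot be separated from compound 2.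

The compounds shown do not tell whether the weakening comes from the chlorine atoms or from the loss of the hydroxyl group. As far as these compounds go, how a plain phenyl, or a ring carrying an amine or a carboxylic acid, would behave on this carbon also remains open.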